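A Halogenated Phenyl Swap on a Scaffold at the Assay Limit

This account rests on a few compounds, and the source may have more. Where it says the series, first, only, none or still open, it means among the compounds named here.

Two spirocyclic compounds were examined in a functional assay on A549 cells (Homo sapiens) for antiproliferative activity, read by MTT assay, with a stated time of 48 h; a lower number here means a stronger inhibitor, a higher number a weaker inhibitor. Compound 1 `Cc1ccc(C)c(-n2nncc2CN2C(=O)C3(C(C#N)=C(N)Oc4c3c3nc5ccccc5nc3c3ccccc43)c3ccccc32)c1` returned > 50000 nM, which is a limit of the measurement and not a number. Compound 2 `COc1ccc(-n2nncc2CN2C(=O)C3(C(C#N)=C(N)Oc4c(N)cc5nc6ccccc6nc5c43)c3ccccc32)cc1` returned > 50000 nM, again a limit rather than a number. Within the data shown here, compound 2 thus stands at the edge of the measurable range alongside the only other value shown, since (the limit of > 50000 nM in this assay, at which 2 of the 2 values shown sit). Among the measured compounds shown here, no step between measured compounds is available here. Compound 3 `N#CC1=C(N)Oc2c(N)cc3nc4ccccc4nc3c2C12C(=O)N(Cc1cnnn1-c1ccc(F)c(Cl)c1)c1ccccc12` is the unmeasured analogue; it differs from compound 2 by 3-chloro-4-fluorophenyl in place of 4-methoxyphenyl on an aromatic nitrogen. With both measured compounds sitting at the limit, the numbers give no direction, so in this assay no step beyond the scatter is expected from compound 2 to compound 3. Compound 3 is expected to give about 50000 nM, within 20000 nM to 100000 nM, most probably reported as a limit once more. The expected step is a number no higher from compound 2 to compound 3 (the limit leaves the size open).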

Compound 3, half-maximal inhibitory concentration: 43400 nM
Compound 3: the middle estimate sits 1.2-fold (0.06 log units) above what was measured; low and high end bracket the measured number.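

The change of 4-methoxyphenyl to 3-chloro-4-fluorophenyl on this aromatic nitrogen gives, in this assay, an at least 1.1-fold lower number from compound 2 to compound 3 (0.06 log units; that floor lies within the scatter). Compound 3, at 43400 nM, is the first compound shown here to return a number rather than a limit, so this position admits a change that brings a reading inside the measurable range. The step has only a floor, which lies within the scatter, and its true size stays unknown: the limit of > 50000 nM in this assay, at which 2 of the 3 values shown sit.

The compounds shown leave open whether chlorine or fluorine alone on the phenyl ring would give a similar reading, since the two enter together. They also leave open whether an amine or a carboxylic acid on that ring, or a longer chain in its place, would give a clearly lower number.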